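Replacing the pyrazole with methyl on the side chain

The source may report more compounds than this note shows. Statements on the series, on what has been measured and on what is new or still open speak of the compounds shown alone.

compound 1 `CCCCNc1nc(N)nc(C)c1CCCCO` — 1310 nM
compound 2 `CCCCNc1nc(N)nc(C)c1CC` — 1660 nM
compound 3 `CCCCNc1nc(N)nc(C)c1CCCn1cccn1` — 1050 nM

In an assay on HEK293 cells for agonist activity at Toll-like receptor 8 (Homo sapiens), read by spectrophotometry (a lower number here means that less compound is needed, a higher number that more compound is needed for the effect), compound 3 gives the lowest of the three numbers, but its separation from the others stays within the scatter: a 1.2-fold lower number from compound 1 to compound 3 (0.10 log units; within the scatter) and a 1.6-fold lower number from compound 2 to compound 3 (0.20 log units; within the scatter). Compound 4 `CCCCNc1nc(N)nc(C)c1CCCC` differs from compound 3 in one place: methyl in place of 1H-pyrazol-1-yl on a saturated chain carbon, three bonds along the chain from an aromatic carbon. The two measured steps into compound 3 are the ones that bear on this change, and both were small; moreover the step of a 1.3-fold higher number from compound 1 to compound 2 (0.10 log units; within the scatter) shows that removing the whole tail altered the number little. A step of no more than the scatter in this assay is therefore expected, in either direction, a 1.3-fold higher number from compound 3 to compound 4 (0.12 log units; within the scatter). Compound 4 is estimated at 1400 nM, with a range from 700 nM to 2800 nM.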

Compound 4, half-maximal effective concentration: 780 nM
The estimate for compound 4 lay 1.8-fold (0.25 log units) above the measured number; the range from low to high includes it.
By their numbers in this assay, from the lowest: compounds 4, 3, 1 and 2 (each within the scatter of the next, the first and the last beyond it).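

In this assay, methyl in place of 1H-pyrazol-1-yl gives a 1.3-fold lower number from compound 3 to compound 4 (0.13 log units; within the scatter), so the ring can be exchanged for methyl at this place without leaving the scatter, and hydrogen in place of hydroxy gives a 1.7-fold lower number from compound 1 to compound 4 (0.23 log units; within the scatter), likewise within it. Ethyl in place of hydrogen gives a 2.1-fold lower number from compound 2 to compound 4 (0.33 log units; beyond the scatter), a modest step and the first among these compounds to lie beyond the scatter. From the compounds shown here alone, whether an amine, a carboxylic acid or a longer chain in place of that methyl would move the number further stays open. Nothing shown here explains these steps.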